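A few compounds are considered here, and "the series" means these few. Any claim that something is new, unique, unknown or untested is made for them only; others in the source may bear on it.

Within the data shown here, compound 2 `S=C(Nc1ccccc1)N1N=C(c2ccc(Br)cc2)CC1c1ccc2c(c1)OCCO2` gives 470 nM in a functional assay on A-375 cells (Homo sapiens) for antiproliferative activity, read by MTT assay, with a stated time of 48 h (a higher number here means a weaker inhibitor of growth, a lower number a stronger inhibitor of growth), the lower of the two numbers measured so far. Among the measured compounds shown here, compound 1 `S=C(Nc1ccccc1)N1N=C(c2ccccc2)CC1c1ccc2c(c1)OCCO2` gives 1850 nM in this assay, and the step of a 3.9-fold lower number from compound 1 to compound 2 (0.60 log units; beyond the scatter) is the only measured step available. Compound 3 `FC(F)(F)c1ccc(C2=NN(C(=S)Nc3ccccc3)C(c3ccc4c(c3)OCCO4)C2)cc1` differs from compound 2 by one change: trifluoromethyl in place of bromo on an aromatic carbon. For the measured compounds named here, no measured step exchanges one such group for another at this position; the step from compound 1 to compound 2 shows only that putting a group there, in place of hydrogen, lowered the number in this assay, and that step was of modest size. Whether swapping bromo for trifluoromethyl moves the number again cannot be read from the data, so the expected step is a 1.1-fold higher number from compound 2 to compound 3 (0.03 log units; within the scatter), within the scatter. Compound 3 is therefore estimated at 500 nM in this assay, with a likely range from 200 nM to 1300 nM.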

Compound 3, concentration for 50% growth inhibition: 43500 nM
Estimate against measurement, compound 3: 87-fold (1.94 log units) below; the whole stated range lies below it.
By their numbers in this assay, from the lowest: compound 2; then compound 1; then compound 3.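

In this assay the exchange of bromo for trifluoromethyl gives a 93-fold higher number from compound 2 to compound 3 (1.97 log units; beyond the scatter) and so shows that this place on the aromatic ring is far more sensitive to the choice of group than the earlier pair could reveal. Trifluoromethyl in place of hydrogen gives a 24-fold higher number from compound 1 to compound 3 (1.37 log units; beyond the scatter) as well, so filling this place does not by itself lower the number: bromo lowered it, while trifluoromethyl raised it well past compound 1. Nothing available bears on what lies behind this split between the two groups.

The compounds shown leave open whether the lower number of compound 2 is particular to bromo or is shared by other groups here, such as chloro, methoxy or an amine. They also leave open whether this exchange would give a step of similar size if the shared core were changed elsewhere.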